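Naphthalenyl ester weighed against two measured aryl esters

The source may report more compounds than this note shows. Statements on the series, on what has been measured and on what is new or still open speak of the compounds shown alone.

Compound 1 `CC(C)(C)c1ccc(OC(=O)c2cn(-c3ccccc3)nc2-c2ccncc2)cc1` gives 33300 nM in a functional assay on Raji cells (Homo sapiens) for cytotoxicity, read by MTT assay, with a stated time of 48 h; on this read-out higher numbers stand for weaker inhibition and lower numbers for stronger inhibition. Within the data shown here, compound 2 `Cc1ccc(C(C)C)c(OC(=O)c2cn(-c3ccccc3)nc2-c2ccncc2)c1` gives 10600 nM in this assay, the lowest of the two numbers, and the only measured step, a 3.1-fold lower number from compound 1 to compound 2 (0.50 log units; beyond the scatter), is the sole guide. Compound 3 `O=C(Oc1ccc2ccccc2c1)c1cn(-c2ccccc2)nc1-c1ccncc1` carries naphthalen-2-yl in place of 2-isopropyl-5-methylphenyl on an oxygen next to a carbonyl group. Among the measured compounds shown here, no measured step exchanges one aromatic ring for a naphthalen-2-yl, so the direction is open; with only the step from compound 1 to compound 2 as a scale, compound 3 is expected to land close to compound 2, at about a 1.1-fold higher number from compound 2 to compound 3 (0.05 log units; within the scatter). The estimated value of compound 3 is 12000 nM, with a range from 4000 nM to 40000 nM.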

Compound 3, half-maximal inhibitory concentration: 12100 nM
The estimate for compound 3 lay 1.0-fold (0.00 log units) below the measured number; the range from low to high includes it.
By their numbers in this assay, from the lowest: compounds 2 and 3 (each within the scatter of the next); then compound 1.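

In this assay, placing naphthalen-2-yl in place of 2-isopropyl-5-methylphenyl on an oxygen next to a carbonyl group gives a 1.1-fold higher number from compound 2 to compound 3 (0.06 log units; within the scatter), so these two groups cannot be told apart at this position. Naphthalen-2-yl in place of 4-(tert-butyl)phenyl gives a 2.8-fold lower number from compound 1 to compound 3 (0.44 log units; beyond the scatter), so 4-(tert-butyl)phenyl now stands apart from two different groups rather than one. Nothing available accounts for these numbers. The compounds shown leave open how naphthalen-1-yl, or a phenyl carrying an amine or a carboxylic acid, would behave at this position. They also leave open whether an amide could replace the ester.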